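The source may report more compounds than this note shows. Statements on the series, on what has been measured and on what is new or still open speak of the compounds shown alone.

Working notes on the series: in a functional assay on HepG2 cells (Homo sapiens) for antiproliferative activity, read by sulforhodamine B assay, with a stated time of 48 h (a higher number here means a weaker inhibitor, a lower number a stronger inhibitor), compound 1 (`c1ccc(CSc2nc(-c3cc4ccccc4[nH]3)n(Cc3ccccc3)n2)cc1`) gives 16.3 ug/mL and compound 2 (`C=CCn1nc(-c2cc3ccccc3[nH]2)nc1SCc1ccccc1`) gives 15.9 ug/mL. The two values lie within the scatter of each other, so compound 1 holds no distinct rank on these numbers. The next structure is compound 3 (`OCCCn1nc(SCc2ccccc2)nc1-c1cc2ccccc2[nH]1`) and it keeps the core of compound 1. The change is 2-hydroxyethyl in place of phenyl on a saturated chain carbon bound to an aromatic nitrogen. Going by the values given here, no step between measured compounds is available to size this change. Among the compounds with values here, the only guide is the closeness of the two measured values. The expected shift in this assay is small, estimated as a 1.2-fold higher number from compound 1 to compound 3 (0.09 log units; within the scatter) with a slight lean toward a higher number and probably none beyond the scatter. The estimated value for compound 3 is 20 ug/mL with an expected range of 9 ug/mL to 45 ug/mL for the measurement.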

Compound 3, half-maximal inhibitory concentration: 11.5 ug/mL
Estimate against measurement, compound 3: 1.7-fold (0.24 log units) above; the range from low to high includes it.
By their numbers in this assay, from the lowest: compounds 3, 2 and 1 (each within the scatter of the next).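

In this assay the exchange of phenyl for 2-hydroxyethyl on a saturated chain carbon bound to an aromatic nitrogen gives a 1.4-fold lower number from compound 1 to compound 3 (0.15 log units; within the scatter) and so stays inside the scatter. Read one bond further out as benzyl to 3-hydroxypropyl, this shows that the six-membered aromatic ring of carbon only can leave this position, and a hydrogen-bond donor and acceptor can enter it, with no shift that can be told from the scatter. No measurement on hand bears on the reason for this result.

From the compounds shown here alone, whether an amine or a carboxylic acid in place of the 2-hydroxyethyl, or a longer chain carrying the same hydroxyl, would move the number beyond the scatter remains open. The only step shown lies within the scatter, so how sensitive this position can be is also unsettled.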